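A few compounds are considered here, and "the series" means these few. Any claim that something is new, unique, unknown or untested is made for them only; others in the source may bear on it.

Values measured in a functional assay on HeLa cells (Homo sapiens) for antiproliferative activity, read by MTT assay, with a stated time of 48 h; a lower number here means a stronger inhibitor, a higher number a weaker inhibitor:
- compound 1 `CCN1CCN(c2nc(Nc3ccc(C(=O)NC4CC(C)(C)N([O])C(C)(C)C4)cc3)ncc2[N+](=O)[O-])CC1`: 17500 nM
- compound 2 `Cc1cc(Nc2nc(Nc3ccc(C(=O)NC4CC(C)(C)N([O])C(C)(C)C4)cc3)ncc2[N+](=O)[O-])no1`: 7360 nM
- compound 3 `Cc1cc(Nc2nc(Nc3ccc(C(=O)NC4CC(C)(C)N([O])C(C)(C)C4)cc3)ncc2F)no1`: 5680 nM

Compound 3 gives 5680 nM, which cannot be told apart from compound 2, since a 1.3-fold lower number from compound 2 to compound 3 (0.11 log units; within the scatter) stays within the usual scatter. Both values sit well under that of compound 1.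

The next compound is compound 4 `CC(C)OC(=O)Cc1csc(Nc2nc(Nc3ccc(C(=O)NC4CC(C)(C)N([O])C(C)(C)C4)cc3)ncc2F)n1`. It carries 4-((isopropoxycarbonyl)methyl)-1,3-thiazol-2-yl in place of 5-methyl-1,2-oxazol-3-yl on a nitrogen on an aromatic ring.

Within the data shown here, no measured step changes the ring on this nitrogen. The closest evidence is a 2.4-fold lower number from compound 1 to compound 2 (0.38 log units; beyond the scatter), a modest step in which (5-methyl-1,2-oxazol-3-yl)amino replaced 4-ethylpiperazin-1-yl on an aromatic carbon. The other step, a 1.3-fold lower number from compound 2 to compound 3 (0.11 log units; within the scatter), swaps fluoro for nitro elsewhere on the molecule and says little here. The new group is also clearly larger than the one it replaces, so the direction remains uncertain. A step of similar modest size is the best guess, leaning slightly towards a lower number. The expected change is a 1.6-fold lower number from compound 3 to compound 4 (0.21 log units; within the scatter). For compound 4 the estimated value in this assay is 3500 nM, with an expected range from 900 nM to 12000 nM.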

Compound 4, half-maximal inhibitory concentration: 11200 nM
Estimate against measurement, compound 4: 3.2-fold (0.51 log units) below, and the stated range covers the measured number.
By their numbers in this assay, from the lowest: compounds 3, 2, 4 and 1 (each within the scatter of the next, the first and the last beyond it).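

Among the compounds shown, this is the only step that changes the group on this nitrogen, and in this assay it reads a 2.0-fold higher number from compound 3 to compound 4 (0.29 log units; within the scatter), so the two compounds cannot be told apart. The position therefore accepts a much larger group: 4-((isopropoxycarbonyl)methyl)-1,3-thiazol-2-yl has 12 heavy atoms and 4 hydrogen-bond acceptors, against 6 and 2 for 5-methyl-1,2-oxazol-3-yl, yet the difference stays inside the normal variation between repeat measurements. Nothing measured here explains why the larger group leaves so little mark on the number.

Because the ring and the side chain change together in this one step, the compounds shown cannot say what each contributes on its own, and a plain 1,3-thiazol-2-yl with no side chain would separate the two. Going by these compounds, it also remains open whether the isopropyl ester itself matters, a question that the free carboxylic acid or a simple primary amide at the end of the same side chain could address.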